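A Methoxy Step on a Silent Benzylamino Compound

The source may hold more compounds than are shown below. What is called first, only, known or untested is meant among the compounds shown, and "the series" means these compounds.

Measured so far in a functional assay on Jurkat cells (Homo sapiens) for inhibition, read by CCK-8 assay, with a stated time of 48 h; on this read-out lower numbers stand for stronger inhibition of growth and higher numbers for weaker inhibition of growth:

Compound 1 `Cc1ccccc1Nc1nc(NCc2ccncc2)ncc1Cl` gives > 100000 nM as a limit of the assay, not a number

Compound 2 `CN1CCN(c2ccc(Nc3ncc(Cl)c(NCc4ccccc4)n3)nc2)CC1` gives > 100000 nM as a limit of the assay, not a number

Compound 2 therefore has no exact position on the scale, only a limit. The same holds across the whole small set, as the limit of > 100000 nM in this assay, at which 2 of the 2 values shown sit, shows. Going by the values given here, no step between measured compounds is available, so nothing yet shows how a single change moves this assay.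

Compound 3 `COc1ccc(CNc2nc(Nc3ccc(N4CCN(C)CC4)cn3)ncc2Cl)cc1` is compound 2 with one change: methoxy in place of hydrogen on an aromatic carbon. Methoxy stands in place of hydrogen on an aromatic carbon, para to a large group, so benzylamino becomes (4-methoxybenzyl)amino.

Only a small change is expected, and if there is any movement it should be towards stronger inhibition of growth. The expectation is modest because the limit of > 100000 nM in this assay, at which 2 of the 2 values shown sit, offers no measured sign of activity to build on. The estimated change is an at least 1.4-fold lower number from compound 2 to compound 3 (0.15 log units; that floor lies within the scatter) and may well not exceed the scatter. For compound 3 the estimated value is 70000 nM with an expected range from 15000 nM to 100000 nM and a strong chance that the assay again reports only a limit.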

Compound 3, concentration for 50% growth inhibition: 12900 nM
Estimate against measurement, compound 3: 5.4-fold (0.73 log units) above; measured number below the stated range.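

In this assay, turning benzylamino into (4-methoxybenzyl)amino gives an at least 7.7-fold lower number from compound 2 to compound 3 (0.88 log units; beyond the scatter), so this single methoxy, para to a large group, is enough to bring a compound of this small set onto the measurable scale. As far as these compounds go, compound 2 carries only a limit, > 100000 nM, so the step is a floor and its true size stays unknown. Compound 3 gives 12900 nM, the only exact number among the compounds shown, and the remaining values offer no second number to set it against: the limit of > 100000 nM in this assay, at which 2 of the 3 values shown sit.

From the compounds shown here alone, what a hydroxy group, a chlorine atom or an ethoxy group would do at the same place stays open, and so does whether the step belongs to methoxy as such or to any group standing there. Compound 1 differs from compound 3 in more than one place and cannot be compared with it, and these values alone do not say why the number moves.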